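Swapping the Aryl Group: Will Tolerance Hold?

The compounds below may be only part of what the source reports. "The series", "measured", "known", "first", "only" and "open" are said of these compounds alone.

Compound 1, `Cc1ccc(-c2cnc(NC(=O)c3ccc(F)cc3)n2C)cc1`: 60000 nM
Compound 2, `COc1ccc(-c2cnc(NC(=O)c3ccccc3C#N)n2C)cc1`: > 100000 nM (a limit of the assay, not a number)

Both measured compounds were tested in a toxicity assay on THP-1 cells (Homo sapiens) for inhibition; a higher number here means that more compound is tolerated, a lower number that less compound is tolerated. Among the measured compounds shown here, compound 1 gives 60000 nM, the only plain number among the two values shown. Compound 2 reaches only a limit of the assay, (the limit of > 100000 nM in this assay, at which 1 of the 2 values shown sits). For the measured compounds named here, nothing beyond these two values can be said about how compound 1 and compound 2 compare, since no step between them has been worked out.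

Compound 3, `Cn1c(-c2cccc(Cl)c2)cnc1NC(=O)c1ccc(F)cc1`, is not yet measured. It differs from compound 1 by 3-chlorophenyl in place of 4-methylphenyl on an aromatic carbon. Going by the values given here, no step between measured compounds is available to guide the expectation, so the step of a 1.2-fold lower number from compound 1 to compound 3 (0.08 log units; within the scatter) is estimated to stay within the usual scatter of this assay, in no particular direction. Compound 3 is therefore expected to give about 50000 nM in this assay, somewhere between 20000 nM and 100000 nM.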

Compound 3, half-maximal cytotoxic concentration: > 50000 nM
Compound 3 gave a limit, no number; the forecaster's own chance of this, stated with the estimate: 35%; the middle value sits exactly at the limit.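

The result for compound 3, > 50000 nM, is a limit of the assay and not a number, so the step between compound 1 and compound 3 cannot be read. From the compounds shown here alone, whether 3-chlorophenyl in place of 4-methylphenyl changes how much compound is tolerated, and in which direction, stays open.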